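Methyl additions in a small cytotoxicity series

This account rests on a few compounds, and the source may have more. Where it says the series, first, only, none or still open, it means among the compounds named here.

Compound 1, `c1ccc(Nc2nc(-n3cnc4ccccc43)cs2)cc1`, opens the set. In a functional assay on RKO cells (Homo sapiens) for cytotoxicity, read by resazurin assay, with a stated time of 72 h (a lower number here means a stronger inhibitor, a higher number a weaker inhibitor), compound 1 gives no number but a limit, > 100000 nM; this is the limit of > 100000 nM in this assay, at which 1 of the 3 values shown sits. Compound 3, `Cc1nc2ccccc2n1-c1csc(Nc2ccccc2)n1`, carries methyl in place of hydrogen on an aromatic carbon and gives 40000 nM in this assay. That change brings an at least 2.5-fold lower number from compound 1 to compound 3 (0.39 log units; beyond the scatter). Compound 2, `Cc1nccn1-c1csc(Nc2ccccc2)n1`, has a core whose difference from compound 1 is not broken down here; in this assay compound 2 gives 32500 nM, a value within the usual scatter of compound 3. Compound 4, `Cc1ccc(Nc2nc(-n3ccnc3C)cs2)cc1`, is not yet measured and differs from compound 2 by methyl in place of hydrogen on an aromatic carbon, the same kind of change as before, but set on a six-membered aromatic ring of carbon only, para to a large group, rather than on a five-membered aromatic ring with 2 nitrogen, part of a fused or bridged system of two rings, between two ring nitrogen atoms. Beside the earlier step, a smaller one, a 1.3-fold lower number from compound 2 to compound 4 (0.11 log units; within the scatter), is expected for compound 4 in this assay. For the measured compounds named here, this expectation rests on the single pair behind an at least 2.5-fold lower number from compound 1 to compound 3 (0.39 log units; beyond the scatter) and on the different place of the methyl. For compound 4 the estimate in this assay is 25000 nM, between 8000 nM and 80000 nM.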

Compound 4, half-maximal inhibitory concentration: 450 nM
Estimate against measurement, compound 4: 56-fold (1.74 log units) above; the whole stated range lies above it.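

Methyl in place of hydrogen on an aromatic carbon, here on a six-membered aromatic ring of carbon only, para to a large group, brings a 72-fold lower number from compound 2 to compound 4 (1.86 log units; beyond the scatter) in this assay. Set beside the earlier step, the size of the two cannot be compared: the same change on two cores in this assay, an at least 2.5-fold lower number (0.39 log units; beyond the scatter) from compound 1 to compound 3 and a 72-fold lower number (1.86 log units; beyond the scatter) from compound 2 to compound 4; the limit leaves it open whether they differ

Compound 1 gives only a limit, > 100000 nM, so the two pairs show a lower number on both cores but no single size that carries from one core to the other, and the methyl sits in a different place in each pair.

Open, going by these compounds, is whether this large step belongs to methyl alone or would also follow from a methoxy group, chlorine or an amine in that place. Also open, on these data alone, is whether methyl in that place brings a similar step on the core of compound 3.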